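A Pyridinyl Swap Tested Against a Cytotoxicity Limit

This account rests on a few compounds, and the source may have more. Where it says the series, first, only, none or still open, it means among the compounds named here.

Compound 1, `COc1ccc([C@H]2CC(=O)N(c3ccccc3)C2)cc1OC1CCCC1`: in a functional assay on HEK293 cells (Homo sapiens) for cytotoxicity (on this read-out higher numbers stand for lower toxicity in this test and lower numbers for higher toxicity in this test), compound 1 gives > 10000 nM, which is a limit of the assay.
Compound 2, `COc1ccc([C@H]2CC(=O)N(c3cc(N)cc(F)c3)C2)cc1OC1CCCC1`: compound 2 gives > 10000 nM, also a limit.
Compound 3, `COc1ccc([C@H]2CC(=O)N(c3ccccc3C)C2)cc1OC1CCCC1`: compound 3 gives > 10000 nM, again a limit.

Compound 1 stands only at a limit, and so do compounds 2 and 3; all three values sit at the same limit (the limit of > 10000 nM in this assay, at which 3 of the 3 values shown sit). The three measured steps, a step that the two limits leave unreadable from compound 1 to compound 2, a step that the two limits leave unreadable from compound 1 to compound 3 and a step that the two limits leave unreadable from compound 2 to compound 3, cannot be sized because every value involved sits at that limit (the limit of > 10000 nM in this assay, at which 3 of the 3 values shown sit).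

Compound 4, `COc1ccc([C@H]2CC(=O)N(c3cccnc3)C2)cc1OC1CCCC1`, differs from compound 1 in one place: pyridin-3-yl in place of phenyl on an amide-type nitrogen in a ring. The changes in a step that the two limits leave unreadable from compound 1 to compound 2 and a step that the two limits leave unreadable from compound 2 to compound 3 also replaced the group on the amide-type nitrogen in a ring, and both stayed unreadable, so they give no direction and no size for the present change. No step beyond the scatter can therefore be foreseen in this assay. Compound 4 is expected to give about 20000 nM, with a range from 8000 nM to 60000 nM, most likely reported as a limit. The estimated step that the limit leaves unreadable from compound 1 to compound 4 is expected to remain unreadable.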

Compound 4, half-maximal cytotoxic concentration: > 10000 nM
Compound 4: a limit, no number; the forecaster's own chance of this, stated with the estimate: 85%; the middle value lies beyond the limit too.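

No step can be read between compound 4 and compound 1, compound 2 or compound 3 in this assay because all four compounds stand at the same limit: the limit of > 10000 nM in this assay, at which 4 of the 4 values shown sit. The compounds shown leave open whether in this assay any group on the amide-type nitrogen in a ring gives a value that is not a limit.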